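A Bromo-to-Methyl Swap and Cell Toxicity

This account rests on a few compounds, and the source may have more. Where it says the series, first, only, none or still open, it means among the compounds named here.

Of the compounds shown here, two have numbers so far in an ADME assay on H9 cells (Homo sapiens) for cytotoxicity, read by XTT assay, with a stated time of 6 days; on this read-out lower numbers stand for higher toxicity in this test and higher numbers for lower toxicity in this test. Compound 1 (`Cc1cccc(C)c1Oc1ccc([N+](=O)[O-])c(Nc2ccc(C#N)cc2)c1`) gives 69600 nM. Compound 2 (`COc1ccc(Nc2cc(Oc3c(C)cc(Br)cc3C)c([N+](=O)[O-])cc2[N+](=O)[O-])cc1`) gives 51200 nM, which lies within the usual scatter of the number for compound 1, so the pair cannot be ranked.

Compound 3 (`COc1ccc(Nc2cc(Oc3c(C)cc(C)cc3C)c([N+](=O)[O-])cc2[N+](=O)[O-])cc1`) has not yet been measured. It differs from compound 2 in one place: methyl in place of bromo on an aromatic carbon. A 4-bromo-2,6-dimethylphenyl group thus becomes a 2,4,6-trimethylphenyl group, with methyl in place of bromo on an aromatic carbon.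

Among the measured compounds shown here, no measured pair of compounds shows this change on its own, so the data offer no direct guide to its size or direction. Compound 1 at 69600 nM and compound 2 at 51200 nM do show two different structures with close numbers, and on that slim basis no step beyond the scatter is expected in this assay. The estimate amounts to a 1.1-fold higher number from compound 2 to compound 3 (0.03 log units; within the scatter), an expected change that stays inside the scatter. For compound 3 the estimated value is 55000 nM, with an expected range from 22000 nM to 120000 nM.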

Compound 3, half-maximal cytotoxic concentration: > 59100 nM
Compound 3 gave a limit, no number; the forecaster's own chance of this, stated with the estimate: 20%; middle value at least 1.0-fold (0.03 log units) from the limit.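

Compound 3 gives a limit of the test and not a number: the limit of > 59100 nM in this assay, at which 1 of the 3 values shown sits.

Among the compounds shown here, that limit still yields the first reading of methyl in place of bromo at this position, para to a large group, with 4-bromo-2,6-dimethylphenyl becoming 2,4,6-trimethylphenyl: an at least 1.1-fold higher number from compound 2 to compound 3 (0.06 log units; that floor lies within the scatter). The swap therefore does not bring the number down in this assay, so a lower number on this ring does not depend on keeping the bromo, though a floor inside the scatter shows only that much and gives no true size for the step.

Still open, on these data alone, is how far the number for compound 3 really sits from that of compound 2, and whether the same swap would give a similar result on a different core. For the compounds shown here, also open is how the read-out would respond to other groups at this position, such as an amine, a carboxylic acid or a longer chain, since bromo and methyl are the only two groups compared here on an otherwise identical structure.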